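This account rests on a few compounds, and the source may have more. Where it says the series, first, only, none or still open, it means among the compounds named here.

Working notes on the series. Compound 1 `CCCCNc1nc(N)nc2c1CN(Cc1ccccn1)CC2` gives 0.07 uM in an assay on HEK293 cells for agonist activity at Toll-like receptor 8 (Homo sapiens), read by a luciferase reporter, with a stated time of 6 h; on this read-out lower numbers stand for an effect already at smaller amounts and higher numbers for an effect only at larger amounts of compound. For the measured compounds named here, compound 2 `CCCCNc1nc(N)nc2c1CN(C(=O)C(C)C)CC2` gives 1.6 uM in this assay, the higher of the two numbers known so far, reached by a 23-fold higher number from compound 1 to compound 2 (1.36 log units; beyond the scatter). Compound 3 `CCCCNc1nc(N)nc2c1CN(C(=O)C1CCC1)CC2` has not yet been measured; it differs from compound 2 by cyclobutyl in place of isopropyl on a carbonyl carbon. Going by the values given here, the one measured step exchanges the whole group on the amine nitrogen in a ring and leaves the carbonyl carbon untouched, so no step bears directly on this change; the two values only show where compound 2 lies. With nothing in the series pointing either way, the step for compound 3 is expected to stay within the scatter, no change at the digits printed from compound 2 to compound 3 (within the scatter). For compound 3 the number in this assay is estimated at 1.6 uM, with a range from 0.6 uM to 4 uM.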

Compound 3, minimum effective concentration: 0.4 uM
For compound 3 the middle estimate is 4.0-fold (0.60 log units) above the measured one; the whole stated range lies above it.
By their numbers in this assay, from the lowest: compound 1; then compound 3; then compound 2.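

In this assay, cyclobutyl in place of isopropyl on a carbonyl carbon gives a 4.0-fold lower number from compound 2 to compound 3 (0.60 log units; beyond the scatter), so the read-out responds to the group on that carbon while the amide-type nitrogen in a ring stays acylated, which the earlier exchange of the whole group could not show. The change closes only part of the gap left by a 23-fold higher number from compound 1 to compound 2 (1.36 log units; beyond the scatter), since (pyridin-2-yl)methyl still gives the lower number, with a 5.7-fold higher number from compound 1 to compound 3 (0.76 log units; beyond the scatter). No measurement at hand offers an explanation for the step from isopropyl to cyclobutyl.

The compounds shown do not separate the effect of the ring from that of the added carbon. Going by these compounds, a straight butyl chain or a cyclopentyl group on the same carbonyl carbon would bear on both points, and the trend beyond cyclobutyl remains open.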